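From Ethyl Ester to Morpholine Amide

The source may report more compounds than this note shows. Statements on the series, on what has been measured and on what is new or still open speak of the compounds shown alone.

In a functional assay on HCT-116 cells (Homo sapiens) for inhibition, read by MTT assay, with a stated time of 72 h (a higher number here means a weaker inhibitor of growth, a lower number a stronger inhibitor of growth), compound 2 `CCOC(=O)/C=C/c1ccncc1-c1ccc2ccccc2c1` gives 910 nM, the lowest number of the three measured. Compound 3 `CNC(=O)CCc1ccncc1-c1ccc2ccccc2c1` gives 19300 nM. Compound 1 `NNC(=O)CCc1ccncc1-c1ccc2ccccc2c1` stands at > 30000 nM, which is a limit and not a number.

Compound 4 `O=C(/C=C/c1ccncc1-c1ccc2ccccc2c1)N1CCOCC1` has morpholin-4-yl in place of ethoxy on a carbonyl carbon. Within the data shown here, two measured steps bear on it, both large: an at least 32-fold lower number from compound 1 to compound 2 (1.51 log units; beyond the scatter) and a 21-fold higher number from compound 2 to compound 3 (1.33 log units; beyond the scatter). Each also replaces the ethenyl chain, so neither isolates this change. Compound 3 is an amide with a higher number, a 21-fold higher number from compound 2 to compound 3 (1.33 log units; beyond the scatter), so a smaller rise in the same direction is expected for compound 4, which keeps the ethenyl chain. The expected change is a 3.3-fold higher number from compound 2 to compound 4 (0.52 log units; beyond the scatter). The estimate for compound 4 is 3000 nM, with an expected range of 700 nM to 15000 nM.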

Compound 4, concentration for 50% growth inhibition: 6040 nM
Beside the measured number, compound 4's estimate is 2.0-fold (0.30 log units) below it; measured number inside the range.
By their numbers in this assay, from the lowest: compound 2; then compound 4; then compound 3. At a limit, above all of these: compound 1.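

In this assay with the ethenyl chain kept, morpholin-4-yl in place of ethoxy on a carbonyl carbon gives a 6.6-fold higher number from compound 2 to compound 4 (0.82 log units; beyond the scatter) and is the first step shown that changes this group alone. The ethyl ester thus keeps the lower number against this amide, and the rise does not need any change to the chain. Nothing measured here accounts for the size of this step.

As far as these compounds go, whether the rise belongs to morpholin-4-yl itself or to amides on this chain generally remains open. A piperidine amide, a simple methyl amide or the carboxylic acid on the ethenyl chain would bear on that.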